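This account rests on a few compounds, and the source may have more. Where it says the series, first, only, none or still open, it means among the compounds named here.

Of the compounds shown here, three have been measured in a functional assay on MX1 cells (Homo sapiens) for inhibition, read by MTT assay, with a stated time of 120 h; on this read-out higher numbers stand for weaker inhibition and lower numbers for stronger inhibition: compound 1 `CC(NC(=O)C#Cc1ccc(NC(=O)Nc2cc(C(F)(F)F)ccc2Cl)cc1)c1ccccc1` gives 16100 nM, compound 2 `O=C(/C=C/c1ccc(NC(=O)Nc2ccc(Cl)c(C(F)(F)F)c2)cc1)NC1CCC1` gives 4530 nM and compound 3 `CC(NC(=O)c1cccc(-c2ccc(NC(=O)Nc3ccc(Cl)c(C(F)(F)F)c3)cc2)c1)c1ccccc1` gives 5240 nM. Compound 2 therefore lies within the scatter of compound 3, while compound 1 has a higher number, meaning weaker inhibition, and that gap lies beyond the scatter. Compound 4 `O=C(CCc1ccc(NC(=O)Nc2ccc(Cl)c(C(F)(F)F)c2)cc1)NC1CCC1` differs from compound 2 in one place, with 2-(cyclobutylcarbamoyl)ethyl in place of 2-(cyclobutylcarbamoyl)ethenyl on an aromatic carbon. Going by the values given here, no measured pair shows this change, so the data offer no direct guide. In this assay the expected change is small, an estimated 1.3-fold higher number from compound 2 to compound 4 (0.12 log units; within the scatter), towards weaker inhibition if it goes anywhere, and possibly nothing beyond the scatter. For compound 4 the estimated value is 6000 nM, with an expected range from 2500 nM to 15000 nM.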

Compound 4, half-maximal inhibitory concentration: 24000 nM
Beside the measured number, compound 4's estimate is 4.0-fold (0.60 log units) below it; the measured number lies above the stated range.
By their numbers in this assay, from the lowest: compounds 2 and 3 (each within the scatter of the next); then compounds 1 and 4 (each within the scatter of the next).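

On an aromatic carbon para to a large group, the two side chains have the same heavy-atom count and differ by one double bond outside aromatic rings, yet in this assay this change gives a 5.3-fold higher number from compound 2 to compound 4 (0.72 log units; beyond the scatter). Going by these compounds alone, this is the first one-place comparison here, and it shows that inhibition is weaker with the 2-(cyclobutylcarbamoyl)ethyl chain than with the 2-(cyclobutylcarbamoyl)ethenyl chain. Nothing available accounts for this difference. Still open, as far as these compounds go, is how a longer chain or a carboxylic acid at this position would compare.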